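Compound 3: hydroxy to ethoxy at the limit

A few compounds are considered here, and "the series" means these few. Any claim that something is new, unique, unknown or untested is made for them only; others in the source may bear on it.

Compound 1 `O=C1OC(Cc2nc(-c3ccc(Oc4ccccc4)cc3)no2)c2ccccc21`: > 40000 nM
Compound 2 `COc1cc(OC)c2c(c1)C(C(O)c1ccc(O)cc1)OC2=O`: > 40000 nM

In an ADME assay on RAW264.7 cells (Mus musculus) for cytotoxicity, read by MTT assay, with a stated time of 24 h, in the presence of a further agent that is not named here (a lower number here means a stronger inhibitor, a higher number a weaker inhibitor), compound 1 gives > 40000 nM, which is a limit of the assay. Compound 2 gives > 40000 nM, also a limit and not a number. The record so far shows (the limit of > 40000 nM in this assay, at which 2 of the 2 values shown sit).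

Compound 3 `CCOc1ccc(C(O)C2OC(=O)c3c(OC)cc(OC)cc32)cc1` differs from compound 2 in one place, hydroxy to ethoxy: ethyl in place of hydrogen on an oxygen on an aromatic ring. Going by the values given here, no measured pair shows this change. The expected size of a number no higher from compound 2 to compound 3 (the limit leaves the size open) is none beyond the scatter, in neither direction. For compound 3 the estimated value is 40000 nM, with an expected range of 20000 nM to 80000 nM.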

Compound 3, half-maximal inhibitory concentration: > 40000 nM
Compound 3: no number, only a limit; the forecaster's own chance of this, stated with the estimate: 80%; the middle value lies on the limit itself.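

In this assay compound 3 gives > 40000 nM, a limit of the assay. Compound 2 also sits at a limit, so no step can be read between compound 2 and compound 3. The compounds shown leave open whether hydroxy to ethoxy changes this read-out at all, and the record stands as follows: the limit of > 40000 nM in this assay, at which 3 of the 3 values shown sit.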